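The source may hold more compounds than are shown below. What is called first, only, known or untested is meant among the compounds shown, and "the series" means these compounds.

In an ADME assay on Huh-5-2 cells (Homo sapiens) for cytotoxicity, read by WST assay, with a stated time of 3 days (on this read-out higher numbers stand for lower toxicity in this test and lower numbers for higher toxicity in this test), compound 1 `COc1ccccc1COc1cc(O)c2c(=O)c(O)c(-c3ccccc3)oc2c1` gives > 100000 nM, which is a limit of the assay rather than a measured number. Compound 2 `O=c1c(O)c(-c2ccccc2)oc2cc(OCc3cccc(Cl)c3)cc(O)c12` likewise reaches only a limit, > 100000 nM. Compound 3 `O=c1c(O)c(-c2ccccc2)oc2cc(OCc3ccc(Br)cc3)cc(O)c12` also stops at a limit, > 100000 nM. Because all three values sit at the same limit (the limit of > 100000 nM in this assay, at which 3 of the 3 values shown sit), the measured steps cannot be read: a step that the two limits leave unreadable from compound 1 to compound 2, a step that the two limits leave unreadable from compound 1 to compound 3 and a step that the two limits leave unreadable from compound 2 to compound 3. Compound 4 `O=c1c(O)c(-c2ccccc2)oc2cc(OCc3ccc([N+](=O)[O-])cc3)cc(O)c12` differs from compound 1 by 4-nitrophenyl in place of 2-methoxyphenyl on a saturated chain carbon bound to an oxygen on an aromatic ring. The two measured swaps at this same place bear on this change, but neither shows a readable size, so no direction can be drawn from them. Compound 4 is therefore expected to remain at the limit as well, with an expected step of a number no higher from compound 1 to compound 4 (the limit leaves the size open). The estimate for compound 4 is 100000 nM, ranging from 40000 nM to 300000 nM.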

Compound 4, half-maximal cytotoxic concentration: 93000 nM
For compound 4 the middle estimate is 1.1-fold (0.03 log units) above the measured one; low and high end bracket the measured number.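

Within the data shown here, compound 4, with 4-nitrobenzyl at this place, is the only compound here that gives a number rather than a limit in this assay. The steps read an at least 1.0-fold lower number from compound 1 to compound 4 (0.03 log units; that floor lies within the scatter), an at least 1.0-fold lower number from compound 3 to compound 4 (0.03 log units; that floor lies within the scatter) and an at least 1.0-fold lower number from compound 2 to compound 4 (0.03 log units; that floor lies within the scatter), so this change shows no difference beyond the scatter. The other three values remain limits: the limit of > 100000 nM in this assay, at which 3 of the 4 values shown sit.

The compounds shown leave open whether an amine or a carboxylic acid on this ring, or a longer chain in place of the benzyl, would bring the number clearly down.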